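The compounds below may be only part of what the source reports. "The series", "measured", "known", "first", "only" and "open" are said of these compounds alone.

Working notes on the series, read in a functional assay on K562 cells (Homo sapiens) for inhibition, read by trypan blue exclusion, with a stated time of 72 h; a lower number here means a stronger inhibitor, a higher number a weaker inhibitor. Of the compounds shown here, three have been measured so far. Compound 2 (`Cn1c(=O)c(S(=O)(=O)c2ccc(F)cc2F)cc2cnc(Nc3cccc4[nH]ccc34)nc21`) gives 1500 nM, the middle of the three values. It is higher than compound 3 (`Cn1c(=O)c(S(=O)(=O)c2ccc(OC(=O)CCCCC3SCC4NC(=O)NC43)cc2)cc2cnc(Nc3ccc4[nH]ccc4c3)nc21`) at 600 nM and lower than compound 1 (`COc1ccc(Nc2ncc3cc(S(=O)(=O)c4ccc(C)cc4)c(=O)n(C)c3n2)cc1`) at 75000 nM.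

The next compound is compound 4 (`Cn1ccc2cc(Nc3ncc4cc(S(=O)(=O)c5ccc(F)cc5F)c(=O)n(C)c4n3)ccc21`), which departs from compound 2 in a single place, on a nitrogen on an aromatic ring: 1-methyl-1H-indol-5-yl in place of 1H-indol-4-yl on a nitrogen on an aromatic ring. In words, 1-methyl-1H-indol-5-yl stands in place of 1H-indol-4-yl, and the count of hydrogen-bond donors in the group falls to none.

For the measured compounds named here, no pair of measured compounds differs in one place only, so the series offers no direct precedent for this change, and the expectation is a loose one. Going by the values given here, it rests on compound 2 at 1500 nM, with compound 3 at 600 nM as the only other value in the same region. Nothing measured points to a large move in either direction, so no change beyond the scatter is expected. The expected step, a 1.3-fold higher number from compound 2 to compound 4 (0.12 log units; within the scatter), reflects that.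

For compound 4 the estimate is 2000 nM, with an expected range from 500 nM to 10000 nM.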

Compound 4, half-maximal inhibitory concentration: 750 nM
The estimate for compound 4 lay 2.7-fold (0.43 log units) above the measured number; measured number inside the range.
By their numbers in this assay, from the lowest: compounds 3, 4 and 2 (each within the scatter of the next, the first and the last beyond it); then compound 1.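

For the compounds shown here, on a nitrogen on an aromatic ring, the exchange of 1H-indol-4-yl for 1-methyl-1H-indol-5-yl gives in this assay a 2.0-fold lower number from compound 2 to compound 4 (0.30 log units; within the scatter) as the first one-place step. The hydrogen-bond donor count of the group falls to none, a methyl group is added and the point of attachment on the indole moves, yet the step stays within the scatter, so at this position the group's donor is not needed to hold the number in this assay, at least with the 1-methyl-1H-indol-5-yl group in place. Nothing measured on these compounds bears on why the two numbers stay so close.

Going by these compounds alone, the single step changes the donor count and the point of attachment together, so their separate contributions remain unresolved, and 1-methyl-1H-indol-4-yl on the same nitrogen would be the group that pulls them apart. Also open, from the compounds shown here alone, is how far this position stretches beyond indoles, for instance to a phenyl ring carrying a morpholine or a carboxylic acid, since every group read here in a one-place step is an indole.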